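A few compounds are considered here, and "the series" means these few. Any claim that something is new, unique, unknown or untested is made for them only; others in the source may bear on it.

Measured compounds:
compound 1 `O=C(C[C@H]1CC[C@]2(CC1)OO[C@]1(O2)C2CC3CC(C2)CC1C3)N1CCNCC1`: 14.4 uL/min
compound 2 `NCCNC(=O)C[C@@H]1CCC[C@]2(C1)OOC1(O2)C2CC3CC(C2)CC1C3`: 8.2 uL/min

In an ADME assay on microsomes from liver (Mus musculus) for metabolic stability (on this read-out higher numbers stand for fast clearance and lower numbers for slow clearance), compound 2 stands at the lower end of the two numbers, and in this assay compound 1 gives a number that sits above it only by a gap within the usual scatter, so the two cannot be told apart on metabolic stability. Compound 3 `NC1CCN(C(=O)C[C@@H]2CCC[C@]3(C2)OOC2(O3)C3CC4CC(C3)CC2C4)CC1` has not yet been measured in this assay. It differs from compound 2 in one place: 4-aminopiperidin-1-yl in place of (2-aminoethyl)amino on a carbonyl carbon. Among the compounds with values here, no step between two measured compounds is available that would show what such a change does in this assay, and compound 1 differs from compound 2 in more than one respect, so its value gives no direct guide. The expectation is therefore built on compound 2 alone, whose value 8.2 uL/min serves as the anchor. The step from compound 2 to compound 3 is expected to be small, a 1.2-fold higher number from compound 2 to compound 3 (0.09 log units; within the scatter), and to fall within the scatter in either direction. Compound 3 is estimated to give 10 uL/min in this assay, with a range from 4 uL/min to 25 uL/min.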

Compound 3, intrinsic clearance in a liver preparation (reported as CLH), per the amount of preparation that the assay uses: 8.2 uL/min
The estimate for compound 3 lay 1.2-fold (0.09 log units) above the measured number, and the stated range covers the measured number.
By their numbers in this assay, from the lowest: compounds 2, 3 and 1 (each within the scatter of the next).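

In this assay, within the data shown here, 4-aminopiperidin-1-yl in place of (2-aminoethyl)amino on a carbonyl carbon gives no change at the digits printed from compound 2 to compound 3 (within the scatter), and this is the first direct reading of a change at this position. For this one pair, an open chain carrying an amine and a six-membered non-aromatic ring carrying an amine cannot be told apart on this read-out, even though the entering group is the larger of the two by heavy atoms. Nothing measured here offers a reason for this outcome.

The compounds shown leave open how the read-out responds when the amine on this group gives way to a hydroxyl group or a carboxylic acid, or when a longer chain such as (3-aminopropyl)amino stands on the same carbonyl carbon. They also leave open what piperazin-1-yl, the group carried by compound 1, would give on the core of compound 2, a comparison that would separate the effect of the group from that of the core.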